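Removing the Phenyl from a Triple-Bonded Carbon

The source may report more compounds than this note shows. Statements on the series, on what has been measured and on what is new or still open speak of the compounds shown alone.

In a functional assay on OVCAR-3 cells (Homo sapiens) for antiproliferative activity, read by WST assay, with a stated time of 72 h (a lower number here means a stronger inhibitor of growth, a higher number a weaker inhibitor of growth), compound 1 (`N=C(N)c1ccc(/N=N/Nc2ccccc2C#Cc2ccccc2)cc1`) gives 8100 nM and so sits at the top of the two numbers available, though not meaningfully apart from the other. In this assay compound 2 (`COc1ccc(C#Cc2cccc(N/N=N/c3ccc(C(=N)N)cc3)c2)cc1`) gives 5200 nM and the two values lie within the scatter of each other, so neither can be ranked over the other.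

The step followed here leads from compound 1 to compound 3 (`C#Cc1ccccc1N/N=N/c1ccc(C(=N)N)cc1`), a change from 2-phenylethynyl to ethynyl, with hydrogen in place of phenyl on a triple-bonded carbon. Within the data shown here, no measured pair differs in one place, so the data give no direct size for this change. Compound 1 at 8100 nM and compound 2 at 5200 nM both keep an aromatic ring on the triple-bonded carbon, and compound 3 has none, so the expectation is an extrapolation.

In this assay a small shift toward weaker growth inhibition is expected, an estimated 1.5-fold higher number from compound 1 to compound 3 (0.17 log units; within the scatter) that may stay within the scatter. For compound 3 the estimate is 12000 nM with an expected range from 4500 nM to 30000 nM in this measurement.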

Compound 3, concentration for 50% growth inhibition: > 25000 nM
Compound 3: no number, only a limit; the forecaster's own chance of this, stated with the estimate: 15%; middle value at least 2.0-fold (0.31 log units) from the limit.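

Compound 1 and compound 2 both keep an aromatic ring on the triple-bonded carbon, so neither could show what that ring contributes to growth inhibition. Replacing the phenyl at this place with hydrogen gives, in this assay, an at least 3.0-fold higher number from compound 1 to compound 3 (0.48 log units; beyond the scatter), so this change carries a cost that lies beyond the scatter, and the ethynyl compound is the weaker inhibitor of growth of the pair. Compound 3 has a limit rather than a number, which makes this step a minimum and leaves its full size unknown: the limit of > 25000 nM in this assay, at which 1 of the 3 values shown sits.

The compounds shown leave open whether an aromatic ring is needed on the triple-bonded carbon at all, or whether a methyl group or a short alkyl chain there would keep the growth inhibition of compound 1, and whether a pyridine ring could stand in for the phenyl. They also leave open whether hydrogen in place of the methoxy-bearing ring of compound 2 would cost a similar amount on that compound's own arrangement of the shared core.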